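Swapping the Amide Substituent on a Weak Kinase Inhibitor

The source may report more compounds than this note shows. Statements on the series, on what has been measured and on what is new or still open speak of the compounds shown alone.

Three measured compounds share one core and differ only in what sits on the amide nitrogen. Compound 1 `CNC(=O)c1ccncc1Nc1cc(-c2ccc3ccn(C)c3c2)c2nccnc2c1` carries a single methyl there; in an assay on lysate for inhibition of 6-phosphofructo-2-kinase/fructose-2,6-bisphosphatase 3 (Homo sapiens), with stated times of 0.5 min and 45 min (a lower number here means a stronger inhibitor, a higher number a weaker inhibitor), compound 1 gives 7020 nM. Among the measured compounds shown here, compound 3 `Cn1cc(CNC(=O)c2ccncc2Nc2cc(-c3ccc4ccn(C)c4c3)c3nccnc3c2)cn1` carries a (1-methyl-1H-pyrazol-4-yl)methyl group instead; in this assay compound 3 gives 75900 nM, the higher of the two numbers known, and the step of an 11-fold higher number from compound 1 to compound 3 (1.03 log units; beyond the scatter) is large. Compound 2 `CN(C)C(=O)c1ccncc1Nc1cc(-c2ccc3ccn(C)c3c2)c2nccnc2c1` has a second methyl on that nitrogen. For compound 2 this assay reports only a limit, > 100000 nM, not a number; this is the limit of > 100000 nM in this assay, at which 1 of the 3 values shown sits. Accordingly the step of an at least 14-fold higher number from compound 1 to compound 2 (1.15 log units; beyond the scatter) is also large, while an at least 1.3-fold lower number from compound 2 to compound 3 (0.11 log units; that floor lies within the scatter) says little.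

Compound 4 `CC(=O)N1CCC(NC(=O)c2ccncc2Nc2cc(-c3ccc4ccn(C)c4c3)c3nccnc3c2)CC1` is not yet measured. Its change from compound 3 is 1-acetylpiperidin-4-yl in place of (1-methyl-1H-pyrazol-4-yl)methyl on an amide-type nitrogen. For the measured compounds named here, both measured steps that altered this nitrogen moved the number upward by a large margin, and the one comparison between two substituted amides stayed within the scatter. Compound 4 keeps a substituted amide of the same kind. Its number is expected to stay near that of compound 3, with the step estimated as a 1.3-fold lower number from compound 3 to compound 4 (0.10 log units; within the scatter). Compound 4 is thus estimated at 60000 nM in this assay, within a range from 15000 nM to 200000 nM.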

Compound 4, half-maximal inhibitory concentration: 31300 nM
Compound 4: middle estimate off by 1.9-fold (0.28 log units), on the high side, and the stated range covers the measured number.
By their numbers in this assay, from the lowest: compound 1; then compound 4; then compound 3. At a limit, above all of these: compound 2.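

The identity of the group on this amide-type nitrogen matters even among larger substituents: in this assay the change from (1-methyl-1H-pyrazol-4-yl)methyl to 1-acetylpiperidin-4-yl gives a 2.4-fold lower number from compound 3 to compound 4 (0.38 log units; beyond the scatter), a difference that the earlier comparison of compound 2 with compound 3 could not show. Still, 1-acetylpiperidin-4-yl does not match the single methyl, as a 4.5-fold higher number from compound 1 to compound 4 (0.65 log units; beyond the scatter) shows, so compound 1 keeps the lowest number of the four. From the compounds shown here alone, compound 2 has only a limit and not a number, so the comparison with it gives only a floor, an at least 3.1-fold lower number from compound 2 to compound 4 (0.50 log units; beyond the scatter), and the true size of that step stays unknown: the limit of > 100000 nM in this assay, at which 1 of the 4 values shown sits.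

Still open, going by these compounds, is whether a small chain such as ethyl, or a small ring such as cyclopropyl, would bring the number closer to that of compound 1. Also open, on these data alone, is what the acetyl group itself contributes, a question that a piperidin-4-yl group with a free ring amine would address, since compound 4 changes the ring and the acetyl together relative to compound 3.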